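The source may report more compounds than this note shows. Statements on the series, on what has been measured and on what is new or still open speak of the compounds shown alone.

Measured in a functional assay on HeLa cells (Homo sapiens) for inhibition, read by MTT assay, with a stated time of 72 h; a lower number here means a stronger inhibitor, a higher number a weaker inhibitor:
compound 1 `COc1ccc(/C=C/C(=O)c2c(OC)cc(O)c(CC=C(C)C)c2O)cc1` gives > 50000 nM (a limit of the assay)
compound 2 `COc1cc(/C=C/C(=O)c2c(OC)cc(O)c(CC=C(C)C)c2O)ccc1O` gives 33800 nM
compound 3 `COc1cc(O)c(CC=C(C)C)c(O)c1C(=O)/C=C/c1ccc(Cl)cc1` gives 16500 nM

Compound 3 has the lowest of the two actual numbers in this assay, at 16500 nM. Going by the values given here, the only other actual number belongs to compound 2, at 33800 nM.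

The next compound is compound 4 `COc1cc(O)c(CC=C(C)C)c(O)c1C(=O)/C=C/c1ccc([N+](=O)[O-])cc1`, with nitro in place of chloro on an aromatic carbon, para to a large group: nitro in place of chloro on an aromatic carbon.

Among the compounds with values here, no measured compound carries nitro, so this change has no direct precedent. The nearest evidence comes from the steps that change the substituted phenyl group on the same chain carbon. Within the data shown here, the step of a 2.0-fold lower number from compound 2 to compound 3 (0.31 log units; beyond the scatter) is the only one between two actual numbers. The step of an at least 3.0-fold lower number from compound 1 to compound 3 (0.48 log units; beyond the scatter) rests on a limit, as does the step of an at least 1.4-fold lower number from compound 1 to compound 2 (0.17 log units; that floor lies within the scatter). These steps are small to modest and give no direction for nitro, so in this assay any change is expected to be modest at most, possibly none beyond the scatter. The expected step is a 1.1-fold higher number from compound 3 to compound 4 (0.04 log units; within the scatter). The estimated value for compound 4 is 18000 nM, with an expected range of 7000 nM to 45000 nM.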

Compound 4, half-maximal inhibitory concentration: 29700 nM
Compound 4: middle estimate off by 1.7-fold (0.22 log units), on the low side; low and high end bracket the measured number.
By their numbers in this assay, from the lowest: compounds 3, 4 and 2 (each within the scatter of the next, the first and the last beyond it). At a limit, above all of these: compound 1.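

In this assay, nitro at this position, on an aromatic carbon para to a large group, does not separate from chloro: a 1.8-fold higher number from compound 3 to compound 4 (0.26 log units; within the scatter). It also does not separate from the 4-hydroxy-3-methoxyphenyl group of the series, with a 1.1-fold lower number from compound 2 to compound 4 (0.06 log units; within the scatter), so compound 4 lies within the scatter of both compounds, although these two are themselves set apart by a 2.0-fold lower number from compound 2 to compound 3 (0.31 log units; beyond the scatter). The value for compound 1 is a limit of the assay, so an at least 1.6-fold lower number from compound 1 to compound 4 (0.22 log units; that floor lies within the scatter) gives only a floor, and the nitro against methoxy comparison stays unresolved at: the limit of > 50000 nM in this assay, at which 1 of the 4 values shown sits.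

The four compounds leave open whether any group at this position gives a step well beyond the scatter, for example an amine or a carboxylic acid in place of nitro or chloro. They also leave open whether the small differences among the 4-chlorophenyl, 4-nitrophenyl and 4-hydroxy-3-methoxyphenyl compounds would persist with a longer chain on the shared core, or in cells other than those of this assay.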